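The source may hold more compounds than are shown below. What is called first, only, known or untested is meant among the compounds shown, and "the series" means these compounds.

Working notes on the series. Of the compounds shown here, three have been measured in an assay on isolated protein for inhibition of kynurenine--oxoglutarate transaminase 1 (Homo sapiens), read by HPLC, with a stated time of 20 min; a lower number here means a stronger inhibitor, a higher number a weaker inhibitor. Compound 1 `Cc1ccc2[nH]c(C(=O)O)c(CCC(=O)O)c2c1` reaches only the limit of the assay, > 1000000 nM, and returns no number. Compound 3 `O=C(O)CCc1c(C(=O)O)[nH]c2ccc(Cl)cc12` differs from compound 1 by a chloro in place of a methyl on an aromatic carbon; in this assay compound 3 gives 293000 nM. The step of an at least 3.4-fold lower number from compound 1 to compound 3 (0.53 log units; beyond the scatter) is reckoned against the limit of compound 1 (the limit of > 1000000 nM in this assay, at which 1 of the 3 values shown sits), so only its least size is known. Compound 2 `CCOC(=O)/C(CCCC(=O)O)=N\Nc1ccc(Cl)cc1`, built on a different core, gives 20000 nM in this assay, the lowest of the two numbers recorded, with compound 3 as the nearest comparison.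

Compound 4 `CCOC(=O)/C(CCCC(=O)O)=N\Nc1cccc(Cl)c1` has not yet been measured. It keeps every atom of compound 2 and changes only the placing of the chlorine: 3-chlorophenyl in place of 4-chlorophenyl on an amine nitrogen. Among the measured compounds shown here, no measured step touches this kind of change; the one step recorded, from compound 1 to compound 3, swaps a substituent on a different core and says nothing about moving a chlorine around a ring. No step beyond the scatter is therefore expected in this assay, and the estimate for compound 4 is set at the value of compound 2: compound 4 is expected to give about 20000 nM, with a range from 6000 nM to 70000 nM, which means an expected step of no change at the digits printed from compound 2 to compound 4 (within the scatter).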

Compound 4, half-maximal inhibitory concentration: 20000 nM
The estimate for compound 4 equals the measured number at the digits printed, within the range that was stated.
By their numbers in this assay, from the lowest: compounds 2 and 4 (each within the scatter of the next); then compound 3. At a limit, above all of these: compound 1.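

In this assay, moving the chlorine from 4-chlorophenyl to 3-chlorophenyl on the amine nitrogen gives no change at the digits printed from compound 2 to compound 4 (within the scatter), so on this core the two placings cannot be told apart. Among the compounds shown here, the earlier compounds could not show this: compound 2 had no partner on its own core, and the only earlier step replaced a methyl with a chloro on the core of compound 1, with a size known only as a least value. The one limit on record concerns compound 1 and does not bear on this pair, so nothing given accounts for the two placings reading alike.

Going by these compounds, the pair tests only the placing of one chlorine, so it remains open whether this position would respond the same way to a different group on the phenyl ring, such as a methoxy group, a nitrile or a trifluoromethyl group, or to a phenyl ring carrying no substituent at all. Also open, on these data alone, is whether the same reading would hold with a carboxylic acid in place of the ethyl ester, or with a shorter chain carrying the acid at the other end of compound 2 and compound 4.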